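Swapping the Aryl Group on a Urea Nitrogen

The compounds below may be only part of what the source reports. "The series", "measured", "known", "first", "only" and "open" are said of these compounds alone.

Of the compounds shown here, three share a core and have been tested in a functional assay for antagonist activity at melanin-concentrating hormone receptor 1 (Homo sapiens); on this read-out lower numbers stand for stronger inhibition and higher numbers for weaker inhibition. Compound 1 `N#Cc1cccc([C@]23CCC(N(CCN4CC[C@@H](O)C4)C(=O)Nc4cc(F)cc(F)c4)CC2C3)c1` gives 15 nM, compound 2 `N#Cc1cccc([C@]23CCC(N(CCN4CC[C@@H](O)C4)C(=O)Nc4cccc(Cl)c4)CC2C3)c1` gives 27 nM, and compound 3 `CC(C)N(CCN(C(=O)Nc1ccc(F)c(Cl)c1)C1CC[C@]2(c3cccc(C#N)c3)CC2C1)C(C)C` gives 4.98 nM, the lowest of the three and beyond the scatter from both others. Going by the values given here, the only measured change at the amide-type nitrogen is a 1.8-fold higher number from compound 1 to compound 2 (0.26 log units; within the scatter), a small movement. Compound 4 `CC(C)N(CCN(C(=O)Nc1cccc(C#N)c1)C1CC[C@]2(c3cccc(C#N)c3)CC2C1)C(C)C` differs from compound 3 by 3-cyanophenyl in place of 3-chloro-4-fluorophenyl on an amide-type nitrogen. One nearby example with a different aryl group suggests such swaps move the number little, so the expected step is a 1.8-fold higher number from compound 3 to compound 4 (0.26 log units; within the scatter), with a slight tilt toward weaker inhibition. Compound 4 is therefore estimated at 9 nM in this assay, with a likely range from 3 nM to 30 nM.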

Compound 4, inhibition constant: 7.6 nM
Compound 4: middle estimate off by 1.2-fold (0.07 log units), on the high side; the measured number falls inside the stated range.
By their numbers in this assay, from the lowest: compounds 3, 4, 1 and 2 (each within the scatter of the next, the first and the last beyond it).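

The step of a 1.5-fold higher number from compound 3 to compound 4 (0.18 log units; within the scatter) shows that a nitrile-bearing ring and a ring bearing two halogens cannot be told apart at this amide-type nitrogen. Going by these compounds alone, the earlier swap, between compounds 1 and 2, only exchanged one halogen-bearing ring for another, so this is the first non-halogen group seen here. Nothing measured here bears on the reason for this closeness. Going by these compounds, whether an unsubstituted phenyl or a ring carrying a methoxy group or an amine would give a similar number remains open, as does whether 3-cyanophenyl behaves the same with the side chain of compound 1.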